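The compounds below may be only part of what the source reports. "The series", "measured", "known", "first", "only" and "open" are said of these compounds alone.

Working notes on the series.

Compound 1 `Cc1ccc(OC2CCN(c3ccc(-n4ccnc4)nn3)CC2)cc1` gives 527 nM in an assay on microsomes from liver for inhibition of acyl-CoA desaturase 1 (Rattus norvegicus); on this read-out higher numbers stand for weaker inhibition and lower numbers for stronger inhibition. Among the three measured compounds it stands second highest; its nearest neighbour is compound 3 `CC(C)(C)c1nnc(-c2ccc(N3CCC(Oc4ccccc4C(F)(F)F)CC3)nn2)s1`, which gives 710 nM, a gap that lies within the scatter, so no order between compound 1 and compound 3 is claimed. Its furthest neighbour is compound 2 `OCc1nnc(-c2ccc(N3CCC(Oc4ccccc4C(F)(F)F)CC3)nn2)s1`, which gives 3.2 nM, a gap well beyond the scatter.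

For the measured compounds named here, the one single-point step in the set is a 220-fold higher number from compound 2 to compound 3 (2.35 log units; beyond the scatter). That step alters the substituent on the core, not the aryl ether, and compounds 2 and 3 differ from compound 1 in more than one place, so it does not bear directly on the change under consideration.

Compound 4 `CCc1ccccc1OC1CCN(c2ccc(-n3ccnc3)nn2)CC1` is not yet measured. It differs from compound 1 as follows: 2-ethylphenyl in place of 4-methylphenyl on an oxygen on a saturated carbon. Going by the values given here, no measured pair isolates this change, and the values of compounds 2 and 3 give no separate reading of the aryl ether, so the expectation rests on compound 1 alone. In this assay compound 4 is therefore expected to stay close to compound 1, with a step of a 1.8-fold lower number from compound 1 to compound 4 (0.24 log units; within the scatter) that may not exceed the scatter. The estimate for compound 4 is 300 nM, with a range of 60 nM to 1500 nM.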

Compound 4, half-maximal inhibitory concentration: 4 nM
Estimate against measurement, compound 4: 75-fold (1.88 log units) above; the whole stated range lies above it.
By their numbers in this assay, from the lowest: compounds 2 and 4 (each within the scatter of the next); then compounds 1 and 3 (each within the scatter of the next).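

Working from compound 1, the group on the oxygen on a saturated carbon proves a strong lever in this assay: 2-ethylphenyl in place of 4-methylphenyl gives a 130-fold lower number from compound 1 to compound 4 (2.12 log units; beyond the scatter). The earlier compounds shown here gave no reading of this place, and this step shows that it can move the number by far more than the scatter, even though the two groups share one six-membered aromatic ring of carbon only, carry no hydrogen-bond donors or acceptors and have no net charge, and differ in heavy atoms only as 8 against 7. No measurement of any property of either group bears on this step, so it stands here as an observation without an explanation.

The step changes both the alkyl group and where it stands on the ring, so the compounds shown do not say how much of it belongs to each; 2-methylphenyl and 4-ethylphenyl on the same oxygen would separate the two. Also open, on these data alone, is whether a longer chain, such as 2-propylphenyl, or an amine on the ring would hold the number of compound 4.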